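Methyl for Bromo on the Anilide Ring

The source may hold more compounds than are shown below. What is called first, only, known or untested is meant among the compounds shown, and "the series" means these compounds.

Compound 1 `O=C(Nc1ccccc1)c1c(NO)cc(-c2ccc(Cl)cc2)oc1=O` gives 11000 nM in an ADME assay on Huh-7 cells (Homo sapiens) for cytotoxicity, read by a luciferase reporter and WST assay, with a stated time of 3 days; on this read-out lower numbers stand for higher toxicity in this test and higher numbers for lower toxicity in this test. Compound 2 `Cc1ccc(-c2cc(NO)c(C(=O)Nc3ccccc3)c(=O)o2)cc1` gives > 20000 nM, which is a limit of this assay rather than a number. Compound 3 `O=C(Nc1ccc(Br)cc1)c1c(NO)cc(-c2ccccc2)oc1=O` gives > 20000 nM, again a limit.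

Compound 3 thus belongs to the group described by the limit of > 20000 nM in this assay, at which 2 of the 3 values shown sit; only a boundary, no exact value, is known for it. Compound 4 `Cc1ccc(NC(=O)c2c(NO)cc(-c3ccccc3)oc2=O)cc1` differs from compound 3 by methyl in place of bromo on an aromatic carbon. Within the data shown here, the single measured step of a comparable kind, a chloro replaced by methyl on the other aromatic ring, gave an at least 1.8-fold higher number from compound 1 to compound 2 (0.25 log units; that floor lies within the scatter) and ended at the limit. The expectation for compound 4 in this assay is therefore no shift beyond the scatter, a step that the limit leaves unreadable from compound 3 to compound 4, most likely another limit. Compound 4 is estimated at 30000 nM, ranging from 15000 nM to 80000 nM.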

Compound 4, half-maximal cytotoxic concentration: > 20000 nM
Compound 4: a limit, no number (the forecaster's own chance of this, stated with the estimate: 75%); the middle value is on the limit's open side.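

The step from compound 3 to compound 4 cannot be read, since both compounds give a limit rather than a number in this assay: the limit of > 20000 nM in this assay, at which 3 of the 4 values shown sit.

The compounds shown leave open whether bromo and methyl differ at all in this assay.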